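Swapping the pyridine substituent: chloro for cyano

A few compounds are considered here, and "the series" means these few. Any claim that something is new, unique, unknown or untested is made for them only; others in the source may bear on it.

Measured in an assay on isolated protein for binding affinity to Adrenergic receptor alpha-1 (Rattus norvegicus); a lower number here means a stronger inhibitor, a higher number a weaker inhibitor:
- compound 1 `COC(=O)c1cccnc1N1CCN(CCCCN2C(=O)SC3(CCCC3)C2=O)CC1` gives 7.8 nM
- compound 2 `O=C1SC2(CCCC2)C(=O)N1CCCCN1CCN(c2ncccc2[N+](=O)[O-])CC1` gives 34.1 nM
- compound 3 `N#Cc1cccnc1N1CCN(CCCCN2C(=O)SC3(CCCC3)C2=O)CC1` gives 35 nM

Compound 3 holds the highest number of the three, yet its value and that of compound 2 lie within the scatter, as the step of a 1.0-fold higher number from compound 2 to compound 3 (0.01 log units; within the scatter) shows; only compound 1 is clearly apart, by a 4.5-fold higher number from compound 1 to compound 3 (0.65 log units; beyond the scatter). Compound 4 `O=C1SC2(CCCC2)C(=O)N1CCCCN1CCN(c2ncccc2Cl)CC1` differs from compound 3 by chloro in place of cyano on an aromatic carbon. Among the measured compounds shown here, no measured step involves chloro, so only the two steps above bear on it: one was within the scatter, the other modest. A small step is therefore expected in this assay, if anything toward a lower number. Compound 4 is estimated at 20 nM, within 6 nM to 70 nM, which means an expected step of a 1.8-fold lower number from compound 3 to compound 4 (0.24 log units; within the scatter).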

Compound 4, half-maximal inhibitory concentration: 19.9 nM
For compound 4 the middle estimate is 1.0-fold (0.00 log units) above the measured one, and the stated range covers the measured number.
By their numbers in this assay, from the lowest: compound 1; then compounds 4, 2 and 3 (each within the scatter of the next).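

In this assay, chloro, which carries no hydrogen-bond acceptor, falls within the scatter of both nitrile-bearing compound 3 and nitro-bearing compound 2, with a 1.8-fold lower number from compound 3 to compound 4 (0.25 log units; within the scatter) and a 1.7-fold lower number from compound 2 to compound 4 (0.23 log units; within the scatter), so an acceptor in this group is not needed to reach that range. Methoxycarbonyl stays apart even from this smaller group, with a 2.6-fold higher number from compound 1 to compound 4 (0.41 log units; beyond the scatter), as it did from cyano and nitro. No evidence given here accounts for these steps.

From the compounds shown here alone, whether an ethyl ester, a carboxylic acid or an amine at this place would match compound 1 remains open.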